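The source may hold more compounds than are shown below. What is called first, only, known or untested is meant among the compounds shown, and "the series" means these compounds.

Working notes on the series:
- compound 1 `C=CCn1nc(-c2cccnc2)c2ccccc2c1=O`: 2140 nM
- compound 2 `COCCn1nc(-c2cccnc2)c2ccccc2c1=O`: 9330 nM
- compound 3 `O=c1c2ccccc2c(-c2cccnc2)nn1CCCCSc1ncccn1`: not yet measured

In a functional assay (trachea) with Cavia porcellus as the target (a higher number here means a weaker inhibitor, a lower number a stronger inhibitor), compound 2 holds the higher of the two numbers at 9330 nM. Compound 3 carries 2-((pyrimidin-2-yl)sulfanyl)ethyl in place of methoxy on a saturated chain carbon, two bonds along the chain from an aromatic nitrogen, that is, 2-((pyrimidin-2-yl)sulfanyl)ethyl in place of methoxy on a saturated chain carbon, two bonds along the chain from an aromatic nitrogen. Among the compounds with values here, only one measured step bears on this chain, the modest 4.4-fold higher number from compound 1 to compound 2 (0.64 log units; beyond the scatter). With methoxy gone, a step of similar size back towards a lower number is tentatively expected, as a 3.7-fold lower number from compound 2 to compound 3 (0.57 log units; beyond the scatter). One step is thin support for so large a change. Compound 3 is estimated at 2500 nM, within a range of 600 nM to 9000 nM.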

Compound 3, half-maximal inhibitory concentration: 6170 nM
Compound 3: the middle estimate sits 2.5-fold (0.39 log units) below what was measured; the measured number falls inside the stated range.
By their numbers in this assay, from the lowest: compound 1; then compounds 3 and 2 (each within the scatter of the next).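

In this assay, the exchange gives a 1.5-fold lower number from compound 2 to compound 3 (0.18 log units; within the scatter), so the two numbers cannot be told apart. The earlier compounds shown here showed only a small swap on this chain; here, 2-((pyrimidin-2-yl)sulfanyl)ethyl, with 9 heavy atoms and a six-membered aromatic ring, takes the place of methoxy and the number stays within the scatter. No evidence available here bears on this result.

Open, as far as these compounds go, is whether a terminal amine or carboxylic acid on the chain would separate from these numbers. Also open, from the compounds shown here alone, is how a plain phenyl ring would compare with the pyrimidine.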